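The source may report more compounds than this note shows. Statements on the series, on what has been measured and on what is new or still open speak of the compounds shown alone.

Three measured compounds share one core and differ only in a single group on an outer benzene ring. Compound 1 `CN(C)C(=O)c1cc2cnc(Nc3ccc(NC(=O)C4(C(=O)Nc5ccccc5)CC4)cc3)nc2n1C1CCCC1` gives 88.8% in a functional assay on A549 cells (Homo sapiens) for inhibition, read by CCK-8 assay, with a stated time of 72 h, tested at 10 uM; a lower number here means less inhibition of growth, a higher number more inhibition of growth at the concentration tested. Compound 2 `CN(C)C(=O)c1cc2cnc(Nc3ccc(NC(=O)C4(C(=O)Nc5ccc(Br)cc5)CC4)cc3)nc2n1C1CCCC1` gives 90.3% in this assay, and compound 3 `Cc1ccc(NC(=O)C2(C(=O)Nc3ccc(Nc4ncc5cc(C(=O)N(C)C)n(C6CCCC6)c5n4)cc3)CC2)cc1` gives 90.6%. Compound 1 carries the lowest of the three numbers, but both of its gaps fall within the usual scatter: a number 1.5 percentage points higher from compound 1 to compound 2 (within the scatter) and a number 1.8 percentage points higher from compound 1 to compound 3 (within the scatter). Likewise a number 0.3 percentage points higher from compound 2 to compound 3 (within the scatter). So far, then, swapping the group on that ring has left growth inhibition unchanged within measurement noise.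

Compound 4 `CN(C)C(=O)c1cc2cnc(Nc3ccc(NC(=O)C4(C(=O)Nc5ccc(C(F)(F)F)cc5)CC4)cc3)nc2n1C1CCCC1` makes the same kind of swap at the same place: trifluoromethyl in place of hydrogen on an aromatic carbon. The two measured steps that bear on it, the bromo step and the methyl step, were both too small to count. A step of no consequence in this assay is therefore expected again, in neither direction beyond the scatter. Compound 4 is estimated at 89.5%, most likely between 82% and 96%, which is expected to mean a number 0.7 percentage points higher from compound 1 to compound 4 (within the scatter).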

Compound 4, percent growth inhibition at one concentration: 87.9%
Compound 4: middle estimate off by 1.6 percentage points, on the high side; measured number inside the range.
By their numbers in this assay, from the lowest: compounds 4, 1, 2 and 3 (each within the scatter of the next).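

In this assay, trifluoromethyl, a group of 4 heavy atoms, leaves the number where it was on this aromatic carbon, with a number 0.9 percentage points lower from compound 1 to compound 4 (within the scatter). It also stands no apart from the two other groups, with a number 2.7 percentage points lower from compound 3 to compound 4 (within the scatter) and a number 2.4 percentage points lower from compound 2 to compound 4 (within the scatter), so hydrogen, bromo, methyl and trifluoromethyl at this one position all lie within the scatter of one another. No measurement shown here explains why the number holds steady across these four compounds.

From the compounds shown here alone, whether an amine or a carboxylic acid on this ring would also leave the number in place stays open. A read-out at a single concentration also leaves open whether these four compounds would still match at lower concentrations.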